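Methoxy Replaced by Morpholinylcarbonyl on a Shared Core

The source may hold more compounds than are shown below. What is called first, only, known or untested is meant among the compounds shown, and "the series" means these compounds.

Of the compounds shown here, three built on a shared core have been measured in a functional assay on HEK293 cells for agonist activity at Free fatty acid receptor 1 (Homo sapiens), read by fluorescence and calcium flux, with a stated time of 10 min; a lower number here means a smaller maximal response, a higher number a larger maximal response. Compound 1 `O=C(O)CCc1ccc(OCC2COc3ccc(Br)cc3O2)cc1F` gives 81% in this assay. Compound 2 `CC#CC(CC(=O)O)c1ccc(OCC2COc3ccc(Cl)cc3O2)cc1` gives 104%. Compound 3 `CC#C[C@@H](CC(=O)O)c1ccc(OC[C@H]2COc3ccc(OC)cc3O2)cc1` gives 91%, which is the second highest of the three numbers: its gap to compound 1 lies within the usual scatter of repeated measurements, whereas its gap to compound 2 lies beyond that scatter.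

Compound 4 `CC#C[C@@H](CC(=O)O)c1ccc(OC[C@H]2COc3ccc(C(=O)N4CCOCC4)cc3O2)cc1` has not yet been measured in this assay. It differs from compound 3 in one place: (morpholin-4-yl)carbonyl in place of methoxy on an aromatic carbon. The change sits on an aromatic carbon of a six-membered aromatic ring of carbon only, part of a fused or bridged system of two rings.

Within the data shown here, no pair of measured compounds reproduces this change, so no step can be read from the data. Since the three measured numbers span only a modest range, compound 4 is expected to show a step of a number 3 percentage points lower from compound 3 to compound 4 (within the scatter) in this assay, a small one in either direction or none beyond the scatter. Compound 4 is estimated to give 88%, within a range from 70% to 105%.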

Compound 4, largest response reached (Emax), in percent of the reference or control that the assay uses: 33%
Beside the measured number, compound 4's estimate is 55 percentage points above it; the measured number lies below the stated range.
By their numbers in this assay, from the lowest: compound 4; then compounds 1 and 3 (each within the scatter of the next); then compound 2.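

In this assay, among these compounds, putting (morpholin-4-yl)carbonyl in place of methoxy on this aromatic carbon brings a number 58 percentage points lower from compound 3 to compound 4 (beyond the scatter) and gives the first step that can be read at this position. It shows that the maximal response depends strongly on what stands here, and that this exchange of a two-heavy-atom methoxy for a larger group with a six-membered non-aromatic ring is not tolerated without a large loss of response. Nothing among the available data gives a reason for this drop.

The compounds shown leave open whether the carbonyl or the morpholine ring goes with the loss. A dimethylaminocarbonyl group, which keeps the carbonyl without the ring, or a morpholin-4-ylmethyl group, which keeps the ring without the carbonyl, would separate the two.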